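A Small Hydroxyethyl Group Replacing a Large Amide

The source may report more compounds than this note shows. Statements on the series, on what has been measured and on what is new or still open speak of the compounds shown alone.

Three compounds share one core. Compound 1 `COc1ccc(C(=O)Nc2nc(-c3ccccc3)nc3c2nnn3Cc2ccccc2F)cc1` gives 21900000 nM in an assay on isolated protein for binding affinity to adenosine receptor A1 (Bos taurus); on this read-out lower numbers stand for stronger inhibition and higher numbers for weaker inhibition. It stands second highest of the three: compound 3 `FC(F)(F)c1ccccc1Cn1nnc2c(NC3CCCCC3)nc(-c3ccccc3)nc21` gives 6800000 nM, a lower number beyond the scatter, while compound 2 `CNc1nc(-c2ccccc2)nc2c1nnn2Cc1ccccc1Cl` gives 191000000 nM, a higher number, also beyond the scatter. Compound 4 `OCCNc1nc(-c2ccccc2)nc2c1nnn2Cc1ccccc1F` is not yet measured. It differs from compound 1 in one place: 2-hydroxyethyl in place of (4-methoxyphenyl)carbonyl on a nitrogen on an aromatic ring. Since compound 2 carries a small group on that nitrogen and gives 191000000 nM, the step of a 2.3-fold higher number from compound 1 to compound 4 (0.36 log units; beyond the scatter) is expected to run toward weaker binding. Compound 4 is therefore estimated at 50000000 nM, with a range from 8000000 nM to 300000000 nM.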

Compound 4, inhibition constant: 54000000 nM
Compound 4: middle estimate off by 1.1-fold (0.03 log units), on the low side; measured number inside the range.
By their numbers in this assay, from the lowest: compound 3; then compound 1; then compound 4; then compound 2.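

In this assay, placing 2-hydroxyethyl in place of (4-methoxyphenyl)carbonyl on this nitrogen gives a 2.5-fold higher number from compound 1 to compound 4 (0.39 log units; beyond the scatter) and so counts as a modest loss of binding. The group that leaves has 10 heavy atoms and an aromatic ring, while the one that enters has 3 heavy atoms and no ring, so this large change in size costs comparatively little. Nothing shown gives a reason for this shift. Which part of the change carries the shift stays open. A 2-aminoethyl group or a longer chain such as 3-hydroxypropyl on that nitrogen could show whether the hydroxyl end or the chain length matters.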